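Phosphate head-group swap on the fluorinated nucleoside core

The source may report more compounds than this note shows. Statements on the series, on what has been measured and on what is new or still open speak of the compounds shown alone.

Compound 1 `O=C(O[C@H]1C[C@H](n2cc(F)c(=O)[nH]c2=O)O[C@@H]1COP(=O)(O)Oc1ccccc1)c1ccccc1` is the reference point of this small set. In a functional assay on T47D cells (Homo sapiens) for cytotoxicity, read by MTT assay, with a stated time of 48 h (on this read-out higher numbers stand for weaker inhibition and lower numbers for stronger inhibition), compound 1 gives 6880 nM, the lowest of the three numbers recorded; compound 3 `CCOC(=O)C[n+]1cccc2cc(OP(=O)([O-])OC[C@H]3O[C@@H](n4cc(F)c(=O)[nH]c4=O)C[C@@H]3OC(=O)c3ccccc3)ccc21` gives 21600 nM and compound 2 `CCCCCCCCCc1ccc(OP(=O)(O)OC[C@H]2O[C@@H](n3cc(F)c(=O)[nH]c3=O)C[C@@H]2OC(=O)c2ccccc2)cc1` gives 26700 nM, both beyond the scatter away from compound 1. Compound 4 `C[N+]1(C)CCC(OP(=O)([O-])OC[C@H]2O[C@@H](n3cc(F)c(=O)[nH]c3=O)C[C@@H]2OC(=O)c2ccccc2)CC1` is not yet measured. It differs from compound 1 in one place: a group of 12 heavy atoms (7 carbon, 1 nitrogen, 3 oxygen, 1 phosphorus; one six-membered non-aromatic ring with 1 hetero atom) in place of a group of 10 heavy atoms (6 carbon, 3 oxygen, 1 phosphorus; one six-membered aromatic ring of carbon only), on an oxygen on a saturated carbon. The ring of carbon only on the phosphate oxygen is thus exchanged for a six-membered non-aromatic ring with one hetero atom, and the hydrogen-bond donor of that part of compound 1 is gone.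

For the measured compounds named here, no measured step covers this exchange directly. Going by the values given here, the only single-site step in the set is a 3.9-fold higher number from compound 1 to compound 2 (0.59 log units; beyond the scatter), a modest weakening. Compound 3 carries a different phosphate-bound ring and its value also lies well above that of compound 1, though its structure differs in more than one place, so only the two values can be compared. Both departures from compound 1 at the phosphate end move the number upward, and on that basis a weakening of similar size is expected for compound 4, a 2.3-fold higher number from compound 1 to compound 4 (0.37 log units; beyond the scatter). Compound 4 is therefore estimated at 16000 nM in this assay, with a range from 5000 nM to 50000 nM.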

Compound 4, half-maximal inhibitory concentration: 11900 nM
Compound 4: middle estimate off by 1.3-fold (0.13 log units), on the high side; the range from low to high includes it.
By their numbers in this assay, from the lowest: compounds 1, 4, 3 and 2 (each within the scatter of the next, the first and the last beyond it).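

Notes on the phosphate end: in this assay, a 1.7-fold higher number from compound 1 to compound 4 (0.24 log units; within the scatter), so the six-membered non-aromatic ring with one hetero atom stands in for the aromatic ring of compound 1 on this oxygen without a readable shift in the number. For the compounds shown here, this is the first exchange in the set that replaces the whole aromatic ring at this place, and it also removes the hydrogen-bond donor of that part; neither the loss of the aromatic ring nor the loss of that donor gives a difference that can be read in this assay. The single-site step in which the ring was kept and nonyl was added, a 3.9-fold higher number from compound 1 to compound 2 (0.59 log units; beyond the scatter), lies beyond the scatter, so among these steps only that one gives a readable change from compound 1.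

Still open, from the compounds shown here alone, is how the number responds to a shorter chain such as propyl in place of nonyl, and whether that step would also lie beyond the scatter. Also open, going by these compounds, is what a piperidine ring with a free amine, lacking the two methyl groups on nitrogen, would give in place of the ring of compound 4.

No measurement on hand accounts for either step.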